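Swapping piperidin-1-yl for diethylamino on a weakly cytotoxic amide

The source may report more compounds than this note shows. Statements on the series, on what has been measured and on what is new or still open speak of the compounds shown alone.

Compound 1 `CCN(CC)CCCN1CC2C(c3ccccc3)CC(N(C)C)(CC2c2ccccc2)C1` gives 3270 nM in an ADME assay on L6 cells (Rattus norvegicus) for cytotoxicity, read by resazurin assay, with a stated time of 72 h; a lower number here means a stronger inhibitor, a higher number a weaker inhibitor
Compound 2 `CN(C)C12CCN(C(=O)CN3CCCCC3)C(C(c3ccccc3)C1)C(c1ccccc1)C2` gives 141000 nM in this assay

Of the two measured compounds, compound 2 stands highest, and its gap to compound 1 lies beyond the scatter. Compound 3 `CCN(CC)CC(=O)N1CCC2(N(C)C)CC(c3ccccc3)C1C(c1ccccc1)C2` is still to be measured in this assay and differs from compound 2 in one place, on a saturated chain carbon bound to a carbonyl carbon: diethylamino in place of piperidin-1-yl on a saturated chain carbon bound to a carbonyl carbon (diethylamino in place of piperidin-1-yl). For the measured compounds named here, no measured pair shows this change, so the expectation rests on compound 2 alone, at 141000 nM in this assay as the nearest structure. No step beyond the scatter is expected, in either direction. The estimate is a small move, a 1.2-fold lower number from compound 2 to compound 3 (0.07 log units; within the scatter) and still within the scatter. Compound 3 is estimated at 120000 nM (expected range 45000 nM to 220000 nM).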

Compound 3, half-maximal inhibitory concentration: 89600 nM
Beside the measured number, compound 3's estimate is 1.3-fold (0.13 log units) above it; low and high end bracket the measured number.
By their numbers in this assay, from the lowest: compound 1; then compounds 3 and 2 (each within the scatter of the next).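

In this assay, for the compounds shown here, diethylamino in place of piperidin-1-yl on a saturated chain carbon bound to a carbonyl carbon gives a 1.6-fold lower number from compound 2 to compound 3 (0.20 log units; within the scatter), the first reading of any change at this position. Within this pair, the six-membered ring of piperidin-1-yl can give way to the ring-free diethylamino group, with one carbon fewer, and the two compounds still cannot be told apart in this assay. No further measurement bears on this result.

Going by these compounds, whether this tolerance extends to other groups at this place remains open, for instance morpholin-4-yl, dimethylamino or a longer chain carrying the amine. A single pair also leaves open whether the same swap would read alike on a different core.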